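A few compounds are considered here, and "the series" means these few. Any claim that something is new, unique, unknown or untested is made for them only; others in the source may bear on it.

Measured so far:
compound 1 `O=C(NO)c1ccc(NCc2nc(-c3ccccc3)nn2-c2ccccc2Cl)cc1` — 64.6%
compound 2 `Cc1ccccc1-c1nc(CNc2ccc(C(=O)NO)cc2)n(-c2ccccc2)n1` — 53.2%

Of the compounds shown here, two have been tested in an assay on Sf9 cells for inhibition of protein deacetylase HDAC6 (Homo sapiens), read by fluorescence, with a stated time of 40 min, tested at 100 nM; a higher number here means more inhibition at the concentration tested (going by the name of the read-out), a lower number less inhibition. Compound 1 `O=C(NO)c1ccc(NCc2nc(-c3ccccc3)nn2-c2ccccc2Cl)cc1` gives 64.6%, the higher of the two numbers. Compound 2 `Cc1ccccc1-c1nc(CNc2ccc(C(=O)NO)cc2)n(-c2ccccc2)n1` gives 53.2%, a number that lies beyond the scatter below compound 1; the two differ in more than one place, so the two values alone are what they show, and no single change can be credited with the gap.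

Compound 3 `CC(C)c1ccc(-n2nc(-c3ccccc3)nc2CNc2ccc(C(=O)NO)cc2)cc1` has not yet been measured. It differs from compound 1 in one place: 4-isopropylphenyl in place of 2-chlorophenyl on an aromatic nitrogen. Within the data shown here, no measured pair shows the effect of changing the group on this aromatic nitrogen by itself, so the direction of the step is open. Given that both measured compounds fall in the same broad band, compound 3 is expected to stay near compound 1, with a step of a number 6.6 percentage points lower from compound 1 to compound 3 (within the scatter) that may well lie within the scatter. Compound 3 is therefore estimated at 58%, between 35% and 80%.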

Compound 3, a percentage reported as inhibition, at one concentration (the size of the read-out at that concentration, not a potency): 52.6%
The estimate for compound 3 lay 5.4 percentage points above the measured number; low and high end bracket the measured number.
By their numbers in this assay, from the lowest: compounds 3 and 2 (each within the scatter of the next); then compound 1.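

On the aromatic nitrogen of the five-membered ring, the change from 2-chlorophenyl to 4-isopropylphenyl gives the series its first step that can be read at a single place: in this assay it amounts to a number 12 percentage points lower from compound 1 to compound 3 (beyond the scatter), so the group at this position does matter for the read-out, at least for this pair. The two groups share one six-membered aromatic ring of carbon only, with no hydrogen-bond donors or acceptors and no net charge, yet the substituent and its place on that ring change together, so the step cannot be credited to either alone. Nothing at hand accounts for the step.

The compounds shown leave open how plain phenyl, 4-chlorophenyl or 2-isopropylphenyl on this nitrogen would compare, and these are the groups that could separate the substituent from its place on the ring. They also leave open whether an amine or a carboxylic acid on this ring, or a cyclohexyl group in place of the ring, would give a higher, lower or level number at this position.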